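Benzamido in place of nitro: working notes

This account rests on a few compounds, and the source may have more. Where it says the series, first, only, none or still open, it means among the compounds named here.

In a functional assay on HepG2 cells (Homo sapiens) for cytotoxicity, read by MTT assay, with a stated time of 72 h (on this read-out lower numbers stand for stronger inhibition and higher numbers for weaker inhibition), compound 3 `CN1CCN(c2ccc(Nc3ncc4nc(Nc5cccc([N+](=O)[O-])c5)n(C5CCCC5)c4n3)cc2)CC1` gives > 5000 nM as a limit of the assay and not a number. Compound 1 `CN1CCN(c2ccc(Nc3ncc4nc(Nc5ccccc5)n(C5CCCCC5)c4n3)cc2)CC1` gives > 5000 nM in this assay as a limit too. Compound 2 `c1ccc(Nc2ncc3nc(Nc4ccccc4)n(C4CCCC4)c3n2)cc1` also gives only a limit with > 5000 nM in this assay for this read-out. Going by the values given here, the series therefore stands at the limit of > 5000 nM in this assay, at which 3 of the 3 values shown sit, and offers no measured step.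

Compound 4 `CN1CCN(c2ccc(Nc3ncc4nc(Nc5cccc(NC(=O)c6ccccc6)c5)n(C5CCCC5)c4n3)cc2)CC1` has benzamido in place of nitro on an aromatic carbon, meta to a large group benzamido in place of nitro on an aromatic carbon and has not yet been measured.

Among the compounds with values here, with no measured step to draw on, the expectation rests on the limit of compound 3 at > 5000 nM in this assay alone. The expected change a number no higher from compound 3 to compound 4 (the limit leaves the size open) is none beyond the usual scatter, with no direction favoured. Another limit is the most likely report. For compound 4 the estimated value is 5000 nM in this assay with an expected range from 1800 nM to 10000 nM as the working interval.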

Compound 4, half-maximal inhibitory concentration: 2600 nM
Beside the measured number, compound 4's estimate is 1.9-fold (0.28 log units) above it; low and high end bracket the measured number.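

In this assay compound 4 gives 2600 nM, the first reading at this position, on an aromatic carbon meta to a large group, that is a number rather than a limit: the limit of > 5000 nM in this assay, at which 3 of the 4 values shown sit.

Benzamido in place of nitro gives an at least 1.9-fold lower number from compound 3 to compound 4 (0.28 log units; that floor lies within the scatter), so only a floor on the change can be read, and that floor does not clear the usual scatter. In this assay, as far as these compounds go, compound 3 gives > 5000 nM, which is a limit of the assay and not a number, so the true size of the step stays open.

The compounds shown do not separate the contribution of the amide link from that of the added aromatic ring; an acetamido or a plain amine at this place would bear on that. They also leave open whether a benzamido carrying a further group, such as a carboxylic acid, would give a different number.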